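Replacing the Sugar Arm of Compound 2 with a Protected Diol

A few compounds are considered here, and "the series" means these few. Any claim that something is new, unique, unknown or untested is made for them only; others in the source may bear on it.

Compound 1 `CN1CCN(CCCCCCn2c3c(c4ccccc42)C(=O)c2c[n+]([O-])c4ccccc4c2C3=O)CC1`: 630 nM; compound 2 `O=C1c2c[n+]([O-])c3ccccc3c2C(=O)c2c1c1ccccc1n2Cc1cn([C@H]2C[C@H](O)[C@@H](CO)O2)nn1`: 390 nM; compound 3 `O=C1c2c[n+]([O-])c3ccccc3c2C(=O)c2c1c1ccccc1n2Cc1cn(C[C@@H](O)CO)nn1`: 140 nM.

In a functional assay on A-375 cells (Homo sapiens) for cytotoxicity, read by MTT assay, with a stated time of 72 h (a higher number here means a weaker inhibitor, a lower number a stronger inhibitor), compound 2 stands second highest of the three numbers; compound 1 lies within the scatter of it, while compound 3 sits beyond it on the lower side. Compound 4 `CC1(C)O[C@@H](CO)[C@H](Cn2cc(Cn3c4c(c5ccccc53)C(=O)c3c[n+]([O-])c5ccccc5c3C4=O)nn2)O1` differs from compound 2 in one place: (5-(hydroxymethyl)-2,2-dimethyl-1,3-dioxolan-4-yl)methyl in place of 4-hydroxy-5-(hydroxymethyl)oxolan-2-yl on an aromatic nitrogen. The step that bears most on this change is a 2.8-fold lower number from compound 2 to compound 3 (0.44 log units; beyond the scatter), where the same 4-hydroxy-5-(hydroxymethyl)oxolan-2-yl group left and a 2,3-dihydroxypropyl chain entered. Among the measured compounds shown here, no measured pair shows a 2,2-dimethyl-1,3-dioxolane in place of a free diol, so that part of the change is untested. a 4.5-fold lower number from compound 1 to compound 3 (0.65 log units; beyond the scatter) adds that compound 3 gives the lowest number. A modest lowering is therefore expected, a 1.6-fold lower number from compound 2 to compound 4 (0.19 log units; within the scatter). Compound 4 is estimated at 250 nM, between 100 nM and 600 nM.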

Compound 4, half-maximal inhibitory concentration: 190 nM
For compound 4 the middle estimate is 1.3-fold (0.12 log units) above the measured one; measured number inside the range.
By their numbers in this assay, from the lowest: compounds 3 and 4 (each within the scatter of the next); then compounds 2 and 1 (each within the scatter of the next).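

In this assay, a 2.1-fold lower number from compound 2 to compound 4 (0.31 log units; beyond the scatter) shows that the 2,3-dihydroxypropyl chain of compound 3 is not the only replacement for 4-hydroxy-5-(hydroxymethyl)oxolan-2-yl on this aromatic nitrogen that lowers the number beyond the scatter. With a 1.4-fold higher number from compound 3 to compound 4 (0.13 log units; within the scatter) inside the scatter, the 2,2-dimethyl-1,3-dioxolane and the free 1,2-dihydroxyethyl are not told apart, so the free diol is not required for the lower number. Nothing available explains either step.

From the compounds shown here alone, whether an amine such as morpholine or a carboxylic acid on this aromatic nitrogen would hold the lower number remains open.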